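This account rests on a few compounds, and the source may have more. Where it says the series, first, only, none or still open, it means among the compounds named here.

Measured compounds:
compound 1 `Cc1cc(-c2nnc3n2CCCCCCC3)c(C)n1-c1ccccc1`: 383 nM
compound 2 `Cc1cccc(-n2cnc3cc(C(=O)N4CCC(Br)CC4)ccc32)c1`: 76 nM
compound 3 `Cc1cccc(-n2cnc3cc(C(=O)N4CCC(C(F)(F)F)CC4)ccc32)c1`: 1520 nM

All three were tested in an assay on isolated protein for inhibition of 15-hydroxyprostaglandin dehydrogenase [NAD(+)] (Homo sapiens), read by fluorescence, with a stated time of 15 min; a higher number here means a weaker inhibitor, a lower number a stronger inhibitor. Compound 2 gives the lowest number of the three, so it is the strongest inhibitor in this set; compound 1 gives a higher number, and compound 3 a still higher one. For the measured compounds named here, the one step between compounds that differ in a single place is a 20-fold higher number from compound 2 to compound 3 (1.30 log units; beyond the scatter).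

Compound 4 `Cc1cccc(-n2cnc3cc(C(=O)NC4CCCC4)ccc32)c1` has not yet been measured. It differs from compound 2 in one place: cyclopentylamino in place of 4-bromopiperidin-1-yl on a carbonyl carbon. Going by the values given here, the measured step concerns a swap of one group for another on the same saturated ring, whereas compound 4 changes the whole group on the carbonyl carbon, so no measured step bears on it directly. With only compound 2 as an anchor, the number for compound 4 is expected to be somewhat higher than that of compound 2, with a wide spread, giving an estimated step of a 3.9-fold higher number from compound 2 to compound 4 (0.60 log units; beyond the scatter). The estimate for compound 4 in this assay is 300 nM, between 60 nM and 1500 nM.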

Compound 4, half-maximal inhibitory concentration: 961 nM
Beside the measured number, compound 4's estimate is 3.2-fold (0.51 log units) below it; measured number inside the range.
By their numbers in this assay, from the lowest: compound 2; then compound 1; then compounds 4 and 3 (each within the scatter of the next).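

Replacing the whole group on the carbonyl carbon can matter as much as changing one substituent on its ring: swapping 4-bromopiperidin-1-yl for cyclopentylamino gives a 13-fold higher number from compound 2 to compound 4 (1.10 log units; beyond the scatter). The earlier step, a 20-fold higher number from compound 2 to compound 3 (1.30 log units; beyond the scatter), kept the piperidine ring, so it could not show this, and both changes now point away from compound 2 while compound 4 and compound 3 sit within the scatter of each other. No available evidence explains why this change raises the number.

This single change alters the ring size, removes the bromo group and brings in the amide hydrogen all at once, and the compounds shown do not separate these parts. Cyclohexylamino, which keeps the amide hydrogen on a six-membered carbon ring, and unsubstituted piperidin-1-yl would each test one part alone.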